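The source may hold more compounds than are shown below. What is called first, only, known or untested is meant among the compounds shown, and "the series" means these compounds.

Measured in a functional assay on HeLa cells (Homo sapiens) for cytotoxicity, read by sulforhodamine B assay, with a stated time of 72 h; a lower number here means a stronger inhibitor, a higher number a weaker inhibitor:
Compound 1 `COc1cccc(/C=C/C(=O)Nc2cc(OC)c(OC)c(OC)c2)c1`: 11300 nM
Compound 2 `COc1cc(/C=C/C(=O)Nc2cc(OC)c(OC)c(OC)c2)cc(OC)c1OC`: > 50000 nM

Compound 2 gives no number in this assay, and its entry of > 50000 nM is only a limit of the assay.

Compound 3 `COc1cc(NC(=O)/C=C/c2cc(OC)c(OC)c(OC)c2)cc(OC)c1` differs from compound 2 in one place, with hydrogen in place of methoxy on an aromatic carbon. That carbon lies ortho to two methoxy groups and para to a large group.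

For the measured compounds named here, no measured pair in this small set shows what such a change does, so any expectation rests on thin ground. Going by the values given here, the only guide is compound 1 at 11300 nM, which shows that a true number can be reached in this assay. A modest move towards stronger inhibition is expected, although compound 3 could well remain at the limit. The estimated size of the change is an at least 1.6-fold lower number from compound 2 to compound 3 (0.22 log units; that floor lies within the scatter). For compound 3 the expected value is 30000 nM, with an estimated range from 9000 nM to 70000 nM.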

Compound 3, half-maximal inhibitory concentration: 38900 nM
Compound 3: middle estimate off by 1.3-fold (0.11 log units), on the low side, within the range that was stated.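

With hydrogen in place of the methoxy on the aromatic carbon ortho to two methoxy groups and para to a large group, compound 3 gives a true number in this assay, 38900 nM, so this position tolerates losing that methoxy without the value staying out of reach. For compound 2, the entry of > 50000 nM is a limit of the assay and not a number. The change can therefore be read only as a floor, an at least 1.2-fold lower number from compound 2 to compound 3 (0.10 log units; that floor lies within the scatter), and its true size remains unknown, a reading bounded by one fact: the limit of > 50000 nM in this assay, at which 1 of the 3 values shown sits.

Going by these compounds, what a hydroxyl, a fluorine atom or an amine on this same carbon would do to the number in this assay stays open, as does whether a longer chain such as ethoxy in place of the methoxy would behave as hydrogen does. For the compounds shown here, also open is whether this change would exceed the scatter from a measurable starting value, and compound 1 and compound 3, the two with true numbers, differ in more than one place and so offer no step of their own.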